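The source may hold more compounds than are shown below. What is called first, only, known or untested is meant among the compounds shown, and "the series" means these compounds.

Measured so far in a functional assay on MCF7 cells (Homo sapiens) for inhibition, read by MTT assay, with a stated time of 48 h; on this read-out lower numbers stand for stronger inhibition and higher numbers for weaker inhibition:
compound 1 `COc1ccc(/C=N/NC(=O)CSc2nnc(-c3ccncc3)n2-c2ccccc2)cc1` gives 23700 nM
compound 2 `O=C(CSc1nnc(-c2ccncc2)n1-c1ccccc1)N/N=C/c1ccc(F)cc1` gives 12300 nM
compound 3 `O=C(CSc1nnc(-c2ccncc2)n1-c1ccccc1)N/N=C/c1cc(Br)cc(Br)c1O` gives 8440 nM

Within the data shown here, compound 3 stands lowest of the three numbers in this assay; its gap to compound 2 lies within the scatter, and only the step of a 2.8-fold lower number from compound 1 to compound 3 (0.45 log units; beyond the scatter) is beyond it. All three measured steps change the aryl group on the carbon with a double bond to nitrogen: a 1.9-fold lower number from compound 1 to compound 2 (0.28 log units; within the scatter) and a 1.5-fold lower number from compound 2 to compound 3 (0.16 log units; within the scatter) are within the scatter, and a 2.8-fold lower number from compound 1 to compound 3 (0.45 log units; beyond the scatter) is modest.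

Compound 4 `O=C(CSc1nnc(-c2ccncc2)n1-c1ccccc1)N/N=C/c1ccc(O)c(O)c1` has not yet been measured. Change from compound 3: 3,4-dihydroxyphenyl in place of 3,5-dibromo-2-hydroxyphenyl on a carbon with a double bond to nitrogen. The three measured steps bear on it only loosely: they show that exchanging this aryl group has moved the number by at most a modest amount, and none of them involves 3,4-dihydroxyphenyl. A step of no more than modest size is therefore expected in this assay, with no firm direction; a slightly higher number is taken as the central guess because compound 3 already holds the lowest number with 8440 nM. For compound 4 the expected step is a 1.4-fold higher number from compound 3 to compound 4 (0.15 log units; within the scatter). The estimate for compound 4 is 12000 nM, within 4000 nM to 35000 nM.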

Compound 4, half-maximal inhibitory concentration: 19700 nM
Beside the measured number, compound 4's estimate is 1.6-fold (0.22 log units) below it; low and high end bracket the measured number.
By their numbers in this assay, from the lowest: compounds 3, 2, 4 and 1 (each within the scatter of the next, the first and the last beyond it).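

In this assay, a 2.3-fold higher number from compound 3 to compound 4 (0.37 log units; beyond the scatter) is a second step at this carbon that lies beyond the scatter, so a hydroxylated aryl group does not by itself keep the number at the level of compound 3. With a 1.2-fold lower number from compound 1 to compound 4 (0.08 log units; within the scatter) and a 1.6-fold higher number from compound 2 to compound 4 (0.20 log units; within the scatter) both within the scatter, 3,4-dihydroxyphenyl cannot be told apart from 4-methoxyphenyl or 4-fluorophenyl here, and the 3,5-dibromo-2-hydroxyphenyl group separates only from 3,4-dihydroxyphenyl and 4-methoxyphenyl, while compound 2 stays within the scatter of all the others. The step from 3,5-dibromo-2-hydroxyphenyl to 3,4-dihydroxyphenyl removes the bromines and rearranges the hydroxy groups in a single change, and no supporting data separate these two parts or explain the shift.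

Still open, as far as these compounds go, is whether the bromines or the hydroxy group carry the difference, which a 3,5-dibromophenyl group on the same carbon would help to settle. Also open, from the compounds shown here alone, is whether a phenyl ring bearing a carboxylic acid or a dimethylamino group at this place would move the number beyond the narrow range seen so far.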